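A few compounds are considered here, and "the series" means these few. Any claim that something is new, unique, unknown or untested is made for them only; others in the source may bear on it.

Three compounds share one core and differ only in the small group attached to it: compound 1 `CC(C)n1nccc1-c1ccccc1NCC1=NCCN1`, compound 2 `Cc1nc(-c2ccccc2NCC2=NCCN2)n(C)n1` and compound 3 `CCn1cc(-c2ccccc2NCC2=NCCN2)cn1`. All three were tested in an in vitro functional assay on cells (Fibroblast) for agonist activity at Alpha-1B adrenergic receptor (Homo sapiens); on this read-out lower numbers stand for an effect already at smaller amounts and higher numbers for an effect only at larger amounts of compound. In this assay compound 1 gives < 100000 nM, which is a limit of the assay and not a measured number. Compound 3 likewise gives < 100000 nM, again a limit rather than a number. Compound 2 gives < 5020 nM, also a limit, though set at a different level. Compound 2 thus stands at the limit of < 5020 nM in this assay, at which 1 of the 3 values shown sits. The other two compounds sit at the limit of < 100000 nM in this assay, at which 2 of the 3 values shown sit. Among the compounds with values here, none of the three has a point value, so no step between them can be sized. The next compound, compound 4 `Cn1ncnc1-c1ccccc1NCC1=NCCN1`, comes from compound 2 by a single change, (hydrogen in place of methyl on an aromatic carbon). Within the data shown here, no measured step is available to guide this change, so the expected step that the limit leaves unreadable from compound 2 to compound 4 is none beyond the usual scatter. Compound 4 is therefore estimated at 3000 nM, with a likely range from 500 nM to 20000 nM.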

Compound 4, half-maximal effective concentration: 39.8 nM
The estimate for compound 4 lay 75-fold (1.88 log units) above the measured number; measured number outside the range, below it.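

No step can be read from compound 2 to compound 4, as compound 2 has only a limit and not a number: the limit of < 5020 nM in this assay, at which 1 of the 4 values shown sits.

The compounds shown leave open how much hydrogen in place of methyl on an aromatic carbon changes the result in this assay.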